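This account rests on a few compounds, and the source may have more. Where it says the series, first, only, none or still open, it means among the compounds named here.

Of the compounds shown here, three sharing one core have been measured in an assay on isolated protein for inhibition of tyrosine-protein kinase receptor UFO (Homo sapiens), read by FRET and Z'-LYTE, with a stated time of 1.5 h; on this read-out higher numbers stand for weaker inhibition and lower numbers for stronger inhibition. Compound 1 `Cc1c(C(=O)Nc2ccc(Oc3ncnc4[nH]cc(-c5ccccc5)c34)c(F)c2)c(=O)c2ccccc2n1C` gives only a limit in this assay, > 10000 nM. Compound 2 `Cc1c(C(=O)Nc2ccc(Oc3ncnc4[nH]cc(-c5ccccc5)c34)c(F)c2)c(=O)c2cc(Cl)ccc2n1C` gives 1890 nM in this assay, and compound 3 `CCc1ccc2c(c1)c(=O)c(C(=O)Nc1ccc(Oc3ncnc4[nH]cc(-c5ccccc5)c34)c(F)c1)c(C)n2C` gives 6 nM. Compound 3 stands lowest of the two numbers shown; its nearest neighbour is compound 2, and the step of a 320-fold lower number from compound 2 to compound 3 (2.50 log units; beyond the scatter) lies beyond the scatter, while an at least 5.2-fold lower number from compound 1 to compound 2 (0.72 log units; beyond the scatter) and an at least 1600-fold lower number from compound 1 to compound 3 (3.22 log units; beyond the scatter) rest on the limit of compound 1 (the limit of > 10000 nM in this assay, at which 1 of the 3 values shown sits). Compound 4 `CCc1ccc2c(c1)c(=O)c(C(=O)Nc1ccc(Oc3ncnc4[nH]ccc34)c(F)c1)c(C)n2C` has not yet been measured; it differs from compound 3 by hydrogen in place of phenyl on an aromatic carbon. Every measured step concerns a substituent on the fused ring of the amide side, and none touches the five-membered ring, so they give no direct guide to this change. Removing a whole phenyl ring is a larger alteration than any step measured here, and a weaker result is expected for compound 4, with the step of a 17-fold higher number from compound 3 to compound 4 (1.22 log units; beyond the scatter) expected to lie beyond the scatter. Compound 4 is therefore estimated at 100 nM, within 15 nM to 1000 nM.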

Compound 4, half-maximal inhibitory concentration: 157 nM
Compound 4: middle estimate off by 1.6-fold (0.20 log units), on the low side; measured number inside the range.
By their numbers in this assay, from the lowest: compound 3; then compound 4; then compound 2. At a limit, above all of these: compound 1.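

In this assay, within the data shown here, the step of a 26-fold higher number from compound 3 to compound 4 (1.42 log units; beyond the scatter) is the first measured change on the five-membered aromatic ring, and it shows that the phenyl at this position counts for much, while the earlier steps showed only the effect of substituents on the fused ring of the amide side. The phenyl is nevertheless not required for inhibition when the ethyl group is present, since compound 4, with hydrogen in its place, still gives 157 nM in this assay. No information given here accounts for the size of this step.

Whether methyl, chloro, or a phenyl carrying an amine at this position would hold the lower number stays open, as only phenyl and hydrogen are shown there. Also open, on these data alone, is what hydrogen in place of phenyl would do on compound 2, with its chloro group.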